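Working notes: trifluoromethyl in place of nitro

The compounds below may be only part of what the source reports. "The series", "measured", "known", "first", "only" and "open" are said of these compounds alone.

compound 1 `COc1cc(O)c(CC=C(C)C)c(O)c1C(=O)/C=C/c1ccc(Cl)cc1` gives 16500 nM
compound 2 `COc1cc(O)c(CC=C(C)C)c(O)c1C(=O)/C=C/c1ccc([N+](=O)[O-])cc1` gives 29700 nM

For the measured compounds named here, in a functional assay on HeLa cells (Homo sapiens) for inhibition, read by MTT assay, with a stated time of 72 h (on this read-out higher numbers stand for weaker inhibition and lower numbers for stronger inhibition), compound 2 stands within the scatter of compound 1, the only other measured compound, so no order is drawn between them. The next change leads to compound 3 `COc1cc(O)c(CC=C(C)C)c(O)c1C(=O)/C=C/c1ccc(C(F)(F)F)cc1` and puts trifluoromethyl in place of nitro on an aromatic carbon. Going by the values given here, the one measured step at this aromatic carbon, nitro in place of chloro, is a 1.8-fold higher number from compound 1 to compound 2 (0.26 log units; within the scatter) and so sets no trend. On that single step, compound 3 is expected to stay close to both measured compounds in this assay with no shift beyond the scatter. The step expected is a 1.4-fold lower number from compound 2 to compound 3 (0.15 log units; within the scatter) and no firm direction is claimed for it. For compound 3 the estimated value is 21000 nM with an expected range from 10000 nM to 42000 nM in this series.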

Compound 3, half-maximal inhibitory concentration: 6800 nM
The estimate for compound 3 lay 3.1-fold (0.49 log units) above the measured number; measured number below the stated range.
By their numbers in this assay, from the lowest: compound 3; then compounds 1 and 2 (each within the scatter of the next).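

In this assay this aromatic carbon now shows a difference beyond the scatter: trifluoromethyl in place of nitro gives a 4.4-fold lower number from compound 2 to compound 3 (0.64 log units; beyond the scatter) and trifluoromethyl in place of chloro gives a 2.4-fold lower number from compound 1 to compound 3 (0.38 log units; beyond the scatter) as well. Chloro and nitro could not be told apart here, so trifluoromethyl is the first group at this carbon to separate from the others, and compound 3 has the lowest number of the three on both printed steps. Nothing available explains why this group stands apart from chloro and nitro.

As far as these compounds go, three groups on one aromatic carbon do not make a trend, and it remains open whether a methoxy group, an amine or a carboxylic acid at this carbon would fall with trifluoromethyl or with chloro and nitro. From the compounds shown here alone, it is also open whether the lower number of compound 3 would carry over to a different core.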